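This account rests on a few compounds, and the source may have more. Where it says the series, first, only, none or still open, it means among the compounds named here.

Working notes on the series, read in a functional assay on NCI-H1975 cells (Homo sapiens) for antiproliferative activity, read by CCK-8 assay, with a stated time of 72 h; a higher number here means a weaker inhibitor of growth, a lower number a stronger inhibitor of growth. Compound 1 `CCC1C(=O)N(C)c2cnc(-n3ccc4cc(C(=O)NC(C)C)ccc43)nc2N1c1ccn(C)n1` gives 12200 nM, second highest of three numbers. Compound 3 `CC[C@@H]1C(=O)N(C)c2cnc(-n3ccc4ccccc43)nc2N1C1CCCC1` stands higher at 28300 nM, and compound 2 `CC[C@@H]1C(=O)N(C)c2cnc(Nc3ccc(S(=O)(=O)NC)cc3)nc2N1C1CCCC1` stands lower at 1410 nM. Both gaps to compound 1 lie beyond the scatter. Compound 4 `CCCCNC(=O)c1ccc2c(ccn2-c2ncc3c(n2)N(c2ccn(C)n2)C(CC)C(=O)N3C)c1` differs from compound 1 in one place: butyl in place of isopropyl on an amide-type nitrogen. Going by the values given here, no measured pair shows a change of this kind, so the expectation rests on compound 1 at 12200 nM and the size of the change alone. The expected 1.1-fold lower number from compound 1 to compound 4 (0.04 log units; within the scatter) stays within the scatter. For compound 4 the estimated value is 11000 nM, with an expected range of 4500 nM to 26000 nM.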

Compound 4, concentration for 50% growth inhibition: 12000 nM
Compound 4: middle estimate off by 1.1-fold (0.04 log units), on the low side; measured number inside the range.
By their numbers in this assay, from the lowest: compound 2; then compounds 4 and 1 (each within the scatter of the next); then compound 3.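

Going by these compounds alone, the first single-place pair of the series, read in this assay and showing a 1.0-fold lower number from compound 1 to compound 4 (0.01 log units; within the scatter) with butyl in place of isopropyl on an amide-type nitrogen, places the two chains within the scatter of each other. At this position on the core of compound 1, these two chains therefore cannot be told apart by growth inhibition. No supporting measurement bears on this result.

Still open, as far as these compounds go, is whether a longer chain, a chain ending in an amine or carboxylic acid, or a cyclopropyl ring on this nitrogen would separate from butyl and isopropyl. From the compounds shown here alone, the same pairing on other versions of the shared core is also open.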